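A few compounds are considered here, and "the series" means these few. Any claim that something is new, unique, unknown or untested is made for them only; others in the source may bear on it.

Measured in a functional assay on MIA PaCa-2 cells (Homo sapiens) for antiproliferative activity, read by MTT assay, with a stated time of 72 h; a higher number here means that more compound is needed for the effect, a lower number that less compound is needed:
Compound 1 `Cc1nn(Cc2ccccc2C(N)=O)c(C)c1NC(=O)c1ccc(COc2ccccc2)cc1`: 42000 nM
Compound 2 `CNC(=O)c1cccc(Cn2nc(C)c(NC(=O)c3ccc(COC4CCCCC4)cc3)c2C)c1`: 14000 nM

Of these two numbers, compound 2 has the lower at 14000 nM, and the number for compound 1 lies above it, beyond the scatter. The next compound to be tested is compound 3 `CNC(=O)c1cccc(Cn2nc(C)c(NC(=O)c3ccc(COc4ccccc4OC)cc3)c2C)c1`. It carries 2-methoxyphenyl in place of cyclohexyl on an oxygen on a saturated carbon. No measured pair of compounds differs in one place only, so the size of this step has not been shown directly. For the measured compounds named here, with compound 1 at 42000 nM as the only other number, a small upward move is expected, and it is not expected to exceed the scatter. The estimated change is a 1.4-fold higher number from compound 2 to compound 3 (0.15 log units; within the scatter). The estimate for compound 3 is 20000 nM, with an expected range from 7000 nM to 60000 nM.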

Compound 3, half-maximal effective concentration: 8500 nM
For compound 3 the middle estimate is 2.4-fold (0.37 log units) above the measured one; the measured number falls inside the stated range.
By their numbers in this assay, from the lowest: compounds 3 and 2 (each within the scatter of the next); then compound 1.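

In this assay, for the compounds shown here, this exchange on an oxygen on a saturated carbon gives the first comparison of compounds that differ in one place only, and it reads a 1.6-fold lower number from compound 2 to compound 3 (0.22 log units; within the scatter) and so stays inside the usual variation between repeats. At this position, then, a six-membered non-aromatic ring of carbon only and a six-membered aromatic ring bearing a methoxy group cannot be told apart by this read-out, even though 2-methoxyphenyl brings one hydrogen-bond acceptor that cyclohexyl lacks. Nothing available here accounts for this result.

Compound 1 differs from compound 2 and compound 3 in more than one place, so its number cannot be tied to any single change. On these data alone, whether an amine, a carboxylic acid or a longer chain on this oxygen would move the number beyond the scatter remains open.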